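The source may report more compounds than this note shows. Statements on the series, on what has been measured and on what is new or still open speak of the compounds shown alone.

Measured in an ADME assay on microsomes from liver (Rattus norvegicus) for pharmacokinetics; a higher number here means faster removal of the compound, a lower number slower removal:
- compound 1 `Cn1cc(-c2ncc(C#N)c(N3C[C@@H]4C[C@H]3CN4CC3CC3)n2)cn1`: 158 mL/min/kg
- compound 2 `Cn1cc(-c2ncc(C#N)c(N3C[C@@H]4C[C@H]3CN4S(=O)(=O)C3CC3)n2)cn1`: < 36 mL/min/kg (a limit)
- compound 3 `Cn1cc(-c2ncc(C#N)c(N3C[C@@H]4C[C@H]3CN4C(=O)C3CC3)n2)cn1`: < 36 mL/min/kg (a limit)

Compound 3 stands only at a limit, < 36 mL/min/kg. This is the limit of < 36 mL/min/kg in this assay, at which 2 of the 3 values shown sit. Compound 4 `Cn1cc(-c2ncc(C#N)c(N3C[C@@H]4C[C@H]3CN4c3cccc(F)c3)n2)cn1` carries 3-fluorophenyl in place of cyclopropylcarbonyl on an amine nitrogen in a ring. For the measured compounds named here, two measured steps bear on this change: an at least 4.3-fold lower number from compound 1 to compound 3 (0.64 log units; beyond the scatter), and an at least 4.3-fold lower number from compound 1 to compound 2 (0.64 log units; beyond the scatter). Both changes put a different group on that same nitrogen, and compound 4 carries neither of the two groups that entered there. Compound 1, with cyclopropylmethyl on that nitrogen, gives 158 mL/min/kg. A move back towards that value is therefore expected, though the size is uncertain. The expected step is an at least 2.5-fold higher number from compound 3 to compound 4 (0.39 log units; beyond the scatter), to a higher number. For compound 4 the estimated value is 90 mL/min/kg, with an expected range of 40 mL/min/kg to 200 mL/min/kg.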

Compound 4, clearance: 1090 mL/min/kg
Compound 4: middle estimate off by 12-fold (1.08 log units), on the low side; measured number above the stated range.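

In this assay, 3-fluorophenyl on this nitrogen gives an at least 30-fold higher number from compound 3 to compound 4 (1.48 log units; beyond the scatter) and an at least 30-fold higher number from compound 2 to compound 4 (1.48 log units; beyond the scatter), and it also passes the cyclopropylmethyl group, with a 6.9-fold higher number from compound 1 to compound 4 (0.84 log units; beyond the scatter). For the compounds shown here, the spread at this position is therefore wider than the earlier compounds showed, and its high end is set here by an aromatic group, not by cyclopropylmethyl. Compound 2 and compound 3 each stand at a limit, so the two larger steps fix only a minimum size: the limit of < 36 mL/min/kg in this assay, at which 2 of the 4 values shown sit.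

Open, on these data alone, is whether the rise comes from the aromatic ring or from its fluorine. A plain phenyl or a benzyl group on this nitrogen would separate the two.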